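Cyclopropylamine in place of 3-chloroaniline on the shared core

A few compounds are considered here, and "the series" means these few. Any claim that something is new, unique, unknown or untested is made for them only; others in the source may bear on it.

Compound 1: `Cc1ccc(NC2=CC(=O)c3nc4n(c3C2=O)[C@H]2OC[C@@H](O)[C@H]2OC4)cc1C`, 2690 nM
Compound 2: `O=C1C(Nc2cccc(Cl)c2)=CC(=O)c2c1nc1n2[C@H]2OC[C@@H](O)[C@H]2OC1`, 7970 nM

In a functional assay on HeLa cells (Homo sapiens) for inhibition, read by sulforhodamine B assay (on this read-out lower numbers stand for stronger inhibition and higher numbers for weaker inhibition), compound 2 stands at the highest of the two numbers; compound 1 gives the lower one, and that gap lies beyond the scatter. Compound 3, `O=C1C(NC2CC2)=CC(=O)c2c1nc1n2[C@H]2OC[C@@H](O)[C@H]2OC1`, keeps the core of compound 2 and alters the amine: cyclopropyl in place of 3-chlorophenyl on an amine nitrogen. No step of this kind is shown among the measured compounds, so the direction is uncertain. Compound 3 is estimated to be a modest step toward a higher number, a 1.5-fold higher number from compound 2 to compound 3 (0.18 log units; within the scatter), and its value is expected to fall around 12000 nM, between 4000 nM and 40000 nM.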

Compound 3, half-maximal inhibitory concentration: > 16000 nM
Compound 3 gave a limit, no number; the forecaster's own chance of this, stated with the estimate: 15%; at least 1.3-fold (0.12 log units) between middle value and limit.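

In this assay compound 3 gives > 16000 nM, which is a limit of the assay and not a number. Cyclopropyl in place of 3-chlorophenyl on an amine nitrogen gives an at least 2.0-fold higher number from compound 2 to compound 3 (0.30 log units; that floor lies within the scatter), the first step shown at this position, and it does not show a gain in inhibition. Its full size stays unknown, because only a floor can be read: the limit of > 16000 nM in this assay, at which 1 of the 3 values shown sits.

Going by these compounds, how a benzyl or cyclohexyl group on this amine nitrogen would read remains open. So does the reading of an unsubstituted phenyl group there.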